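Chloro in Place of Methyl at the Far Aryl Ring

The source may report more compounds than this note shows. Statements on the series, on what has been measured and on what is new or still open speak of the compounds shown alone.

The measured compounds:
Compound 1, `CCOC(=O)c1cc2cc(/C=C/C(=O)c3ccc(C)cc3)cc(C(C)CC)c2oc1=O`, gives 3590 nM.
Compound 2, `CCC(C)c1cc(C=O)cc2cc(C(C)=O)c(=O)oc12`, gives 70000 nM.
Compound 3, `CCOC(=O)c1cc2cc(C=O)cc(C(C)CC)c2oc1=O`, gives 64300 nM.

All three were tested in a functional assay on C-33-A cells (Homo sapiens) for cytotoxicity, read by sulforhodamine B assay, with a stated time of 48 h; a lower number here means a stronger inhibitor, a higher number a weaker inhibitor. Compound 1 gives the lowest number of the three, and the other two stand well beyond the scatter above it. Going by the values given here, the only measured step between neighbours, a 1.1-fold lower number from compound 2 to compound 3 (0.04 log units; within the scatter), concerns a change at the carbonyl carbon, not at an aromatic ring.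

Compound 4, `CCOC(=O)c1cc2cc(/C=C/C(=O)c3ccc(Cl)cc3)cc(C(C)CC)c2oc1=O`, differs from compound 1 by one change: chloro in place of methyl on an aromatic carbon. Among the compounds with values here, no measured step touches this aromatic ring, so the one step on record says nothing direct about it; it only shows that a small swap elsewhere left the number within the scatter. Compound 4 is therefore expected to give 3500 nM, in the range 1200 nM to 10000 nM. The step of a 1.0-fold lower number from compound 1 to compound 4 (0.01 log units; within the scatter) is expected to stay within the scatter, with wide uncertainty in either direction.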

Compound 4, half-maximal inhibitory concentration: 4540 nM
For compound 4 the middle estimate is 1.3-fold (0.11 log units) below the measured one; the measured number falls inside the stated range.
By their numbers in this assay, from the lowest: compounds 1 and 4 (each within the scatter of the next); then compounds 3 and 2 (each within the scatter of the next).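

In this assay the change from 4-methylphenyl to 4-chlorophenyl gives a 1.3-fold higher number from compound 1 to compound 4 (0.10 log units; within the scatter) and so leaves the two numbers indistinguishable. Going by these compounds alone, this is the first direct reading at this aromatic carbon, since the only earlier step concerned a carbonyl carbon and none touched the far ring. Here, then, one heavy atom can be exchanged for another on that ring with no change that rises above the usual scatter, though nothing available explains why methyl and chloro read alike.

From the compounds shown here alone, one swap says little about the position as a whole, so it remains open how a larger or quite different group on the same aromatic carbon, such as an amine, a carboxylic acid or a longer chain, would read. Going by these compounds, whether a hydrogen there would give a similar number also remains open.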